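The compounds below may be only part of what the source reports. "The series", "measured", "known", "first", "only" and "open" are said of these compounds alone.

Compound 3, `COc1cccc(CNCCCNc2ccnc3cc(Cc4cccc(C(F)(F)F)c4)ccc23)c1O`, gives 9.47 in a physicochemical assay for acid dissociation. Compound 1, `COc1ccc(-c2ccc3c(NCCCNCc4cccc(OC)c4O)ccnc3c2)cc1`, gives 9.47, and compound 2, `COc1cccc(Oc2ccc3c(NCCCNCc4cccc(OC)c4O)ccnc3c2)c1`, gives 9.28; compound 3 matches compound 1, the two sitting at the top of these three numbers, and all three lie within the scatter of one another. The next compound is compound 4, `COc1cccc(CNCCCNc2ccnc3cc(-c4ccccc4)ccc23)c1O`: phenyl in place of 3-(trifluoromethyl)benzyl on an aromatic carbon. Among the compounds with values here, the steps that bear on this change each swap the group on that same aromatic carbon: no change at the digits printed from compound 1 to compound 3 (within the scatter), a number 0.19 log units higher from compound 2 to compound 3 (within the scatter), and a number 0.19 log units lower from compound 1 to compound 2 (within the scatter). None of them shifted this assay beyond the scatter, so the step to compound 4 is expected to be negligible as well, a number 0.02 log units lower from compound 3 to compound 4 (within the scatter). Compound 4 is therefore estimated at 9.45, with a likely range from 9.15 to 9.75.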

Compound 4, acid dissociation constant: 9.47
For compound 4 the middle estimate is 0.02 log units below the measured one; measured number inside the range.
By their numbers in this assay, from the lowest: compounds 2, 1, 3 and 4 (each within the scatter of the next).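

In this assay plain phenyl takes the place of the group on this aromatic carbon, with 11 heavy atoms leaving and 6 entering. The result is no change at the digits printed from compound 3 to compound 4 (within the scatter). Set against the other two groups, the bare ring gives a number 0.19 log units higher from compound 2 to compound 4 (within the scatter) and no change at the digits printed from compound 1 to compound 4 (within the scatter), so neither the fluorines nor the methoxy is needed to hold this number. All four groups at this position now lie within the scatter of one another.

Nothing available gives a reason for this flat result. Each group shown carries a six-membered aromatic ring of carbon only, so an amine or a carboxylic acid on this carbon remains an open case.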